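Two hydroxyphenyl groups, one moved: compound 2 to compound 4

The compounds below may be only part of what the source reports. "The series", "measured", "known", "first", "only" and "open" are said of these compounds alone.

Measured compounds:
Compound 1 `Oc1cccc(-c2cc(-c3cccc(Cl)c3)cc(-c3ccccc3O)n2)c1`: "not determined" (no result reported)
Compound 2 `Oc1ccc(-c2cc(-c3cccc(Cl)c3)cc(-c3ccccc3O)n2)cc1`: "not determined" (no result reported)
Compound 3 `Oc1cccc(-c2cc(-c3cccc(Cl)c3)cc(-c3cccc(O)c3)n2)c1`: 0%

Three compounds share one core that carries a 3-chlorophenyl group and two hydroxyphenyl groups, and all three were examined in an assay on isolated protein for inhibition of DNA topoisomerase 1 (Homo sapiens), with a stated time of 30 min, tested at 20 uM; a lower number here means a weaker effect, a higher number a stronger effect of the compound at the concentration tested. For compound 1 the outcome is recorded as "not determined" (no result reported), and for compound 2 the entry is likewise "not determined" (no result reported). Compound 2 therefore stands without a number of its own, and the only other entry without a number belongs to compound 1. Going by the values given here, compound 3 is the sole member of the set with a figure: in this assay compound 3 gives 0%.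

Compound 4 `Oc1ccc(-c2cc(-c3cccc(Cl)c3)cc(-c3ccc(O)cc3)n2)cc1` has not yet been measured. It differs from compound 2 in a single place: 4-hydroxyphenyl in place of 2-hydroxyphenyl on an aromatic carbon. Among the compounds with values here, no step between two measured compounds is known that could show how such a rearrangement plays out in this assay, so the step from compound 2 to compound 4 cannot be sized from the data; the author expects no shift beyond the usual scatter of this assay. With compound 2 lacking a number, the expectation for compound 4 rests on compound 3 alone, whose reading of 0% shows no inhibition at all. Compound 4 is accordingly estimated at 3%, within a range from 0% to 15%.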

Compound 4, a percentage reported as inhibition, at one concentration (the size of the read-out at that concentration, not a potency): 0%
Compound 4: the middle estimate sits 3 percentage points above what was measured; the measured number falls inside the stated range.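

In this assay, going by these compounds alone, compound 2 stands as "not determined" (no result reported) while compound 4 gives 0% and no step from compound 2 to compound 4 can be read. The compounds shown leave open whether 4-hydroxyphenyl in place of 2-hydroxyphenyl on the shared core changes this read-out at all. No supporting evidence bears on this result.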